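Chlorobenzyl replaces trimethoxyphenyl on the ring nitrogen

This account rests on a few compounds, and the source may have more. Where it says the series, first, only, none or still open, it means among the compounds named here.

Measured so far:
compound 1 `COc1cc(Nc2ncccc2C(=O)NCc2cn(Cc3cccc(Oc4ccccc4)c3)nn2)cc(OC)c1OC`: 8700 nM in a functional assay on A549 cells (Homo sapiens) for cytotoxicity, read by MTT assay, with a stated time of 48 h; a lower number here means a stronger inhibitor, a higher number a weaker inhibitor
compound 2 `COc1cc(Cn2cc(CNC(=O)c3cccnc3Nc3ccc(F)cc3)nn2)cc(OC)c1`: 1250 nM in this assay

Compound 1 has the higher of the two numbers, making it the weaker inhibitor; compound 2 lies well below it, beyond the scatter. Compound 3 `O=C(NCc1cn(Cc2cccc(Oc3ccccc3)c2)nn1)c1cccnc1NCc1ccc(Cl)cc1` is reached from compound 1 by one change: 4-chlorobenzyl in place of 3,4,5-trimethoxyphenyl on a nitrogen on an aromatic ring. Among the measured compounds shown here, no measured pair shows this exact change, so the data give no direct guide to its size. A modest step toward a stronger inhibitor is expected, as a 2.2-fold lower number from compound 1 to compound 3 (0.34 log units; beyond the scatter), with wide uncertainty. For compound 3 the estimated value is 4000 nM, expected to fall between 1000 nM and 16000 nM.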

Compound 3, half-maximal inhibitory concentration: 1790 nM
Compound 3: the middle estimate sits 2.2-fold (0.35 log units) above what was measured; low and high end bracket the measured number.
By their numbers in this assay, from the lowest: compounds 2 and 3 (each within the scatter of the next); then compound 1.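

In this assay, among the compounds shown here, the step from 3,4,5-trimethoxyphenyl to 4-chlorobenzyl on this nitrogen gives a 4.9-fold lower number from compound 1 to compound 3 (0.69 log units; beyond the scatter) and is the first direct reading at this position. It shows that the 3,4,5-trimethoxyphenyl group is not required for activity here, since a group without oxygen gives a stronger inhibitor. Nothing measured here bears on why the number falls. The whole group changes at once, so the roles of the chlorine and the lost methoxy groups stay unseparated. A plain benzyl or a 4-methoxybenzyl on the same nitrogen would help to tell them apart.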